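A few compounds are considered here, and "the series" means these few. Any claim that something is new, unique, unknown or untested is made for them only; others in the source may bear on it.

Compound 1, `COc1ccccc1/C=C1\NS(=O)(=O)c2ccccc2C1=O`: 1240 nM
Compound 2, `O=C1/C(=C/c2cccc(Br)c2)NS(=O)(=O)c2ccccc21`: 2550 nM

In an assay for inhibition of Intestinal-type alkaline phosphatase (Homo sapiens), read by spectrophotometry, with stated times of 10 min and 20 min (on this read-out lower numbers stand for stronger inhibition and higher numbers for weaker inhibition), compound 2 gives the higher of the two numbers on record; the number for compound 1 lies below it, and the gap is beyond the usual scatter. Compound 3, `O=C1/C(=C/c2cccc(O)c2)NS(=O)(=O)c2ccccc21`, differs from compound 2 only by hydroxy in place of bromo on an aromatic carbon. Within the data shown here, no measured pair shows this same exchange, so the expectation rests on compound 2 alone. Compound 3 is estimated at 3000 nM, within 1000 nM to 9000 nM. The step from compound 2 to compound 3 is expected to be a 1.2-fold higher number from compound 2 to compound 3 (0.07 log units; within the scatter), likely no larger than the scatter, in either direction.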

Compound 3, half-maximal inhibitory concentration: 1210 nM
Compound 3: middle estimate off by 2.5-fold (0.39 log units), on the high side, and the stated range covers the measured number.
By their numbers in this assay, from the lowest: compounds 3 and 1 (each within the scatter of the next); then compound 2.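

In this assay, among these compounds, the change from 3-bromophenyl to 3-hydroxyphenyl gives a 2.1-fold lower number from compound 2 to compound 3 (0.32 log units; beyond the scatter), the first step that can be read between compounds differing in one place. It shows that the number responds to the group at this aromatic carbon, and that hydroxy is tolerated there in place of bromo. Nothing at hand accounts for the size or direction of this step. The compounds shown leave open how an amine or a carboxylic acid would compare at this same carbon. They also leave open whether this exchange would give a similar step on another compound.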